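A few compounds are considered here, and "the series" means these few. Any claim that something is new, unique, unknown or untested is made for them only; others in the source may bear on it.

Among the compounds with values here, compound 2 `COc1ccc(OC(=O)N2CCC(C(O)(c3ccccc3)c3ccccc3)CC2)cc1` gives 2680 nM in a functional assay for antagonist activity at Neuropeptide Y receptor type 2 (Homo sapiens) (a higher number here means a weaker inhibitor, a lower number a stronger inhibitor), and holds the higher of the two numbers so far; the nearer one belongs to compound 1 `OC(c1ccccc1)(c1ccccc1)C1CCN(C(=S)Nc2ccc(C(F)(F)F)cc2)CC1`, which gives 178 nM in this assay, a gap beyond the usual scatter. Compound 3 `CCS(=O)(=O)c1ccc(OC(=O)N2CCC(C(O)(c3ccccc3)c3ccccc3)CC2)cc1` differs from compound 2 by ethylsulfonyl in place of methoxy on an aromatic carbon. Within the data shown here, no step between measured compounds shows such a change, so nothing here points in either direction, and the step of a 1.2-fold lower number from compound 2 to compound 3 (0.09 log units; within the scatter) is expected to stay within the scatter. Compound 3 is therefore estimated at 2200 nM in this assay, within a range from 500 nM to 9000 nM.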

Compound 3, half-maximal inhibitory concentration: 59 nM
Compound 3: middle estimate off by 37-fold (1.57 log units), on the high side, outside the stated range (below it).
By their numbers in this assay, from the lowest: compound 3; then compound 1; then compound 2.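

At this aromatic carbon, para to a large group, the choice of substituent carries real weight in this assay: ethylsulfonyl in place of methoxy gives a 45-fold lower number from compound 2 to compound 3 (1.66 log units; beyond the scatter). Within the data shown here, the earlier compounds offered no step at this place, so this is the first reading of how sensitive it is. No measurement shown accounts for the size of this step.

On these data alone, whether the sulfonyl or its ethyl chain carries the change remains open. So does how an amine, a carboxylic acid or a longer chain on the sulfonyl would fare at this carbon.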